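The compounds below may be only part of what the source reports. "The series", "measured", "known", "first", "only" and "open" are said of these compounds alone.

In a functional assay (thoracic aorta) for inhibition, with Rattus norvegicus as the target (a higher number here means a weaker inhibitor, a lower number a stronger inhibitor), compound 1 (`O=C(O)c1cc(CCCNS(=O)(=O)c2ccccc2)c2cccccc1-2`) gives 4800 nM, while compound 2 (`CC(C)c1ccc2c(CCCCNS(=O)(=O)c3ccc(Cl)cc3)cc(C(=O)O)c-2cc1`) gives 5.3 nM, the lower of the two numbers and a gap well beyond the scatter. Compound 3 (`CC(C)c1ccc2c(CCCCNS(=O)(=O)c3ccc(F)cc3)cc(C(=O)O)c-2cc1`) changes compound 2 in one place: fluoro in place of chloro on an aromatic carbon, with fluoro in place of chloro on an aromatic carbon. Among the compounds with values here, no measured pair shows this swap, so the expectation is only a small move, perhaps toward a slightly higher number and possibly within the scatter. The expected size of this move is a 1.5-fold higher number from compound 2 to compound 3 (0.18 log units; within the scatter). The estimate for compound 3 is 8 nM, with an expected range of 2.5 nM to 25 nM.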

Compound 3, half-maximal inhibitory concentration: 11 nM
Beside the measured number, compound 3's estimate is 1.4-fold (0.14 log units) below it, and the stated range covers the measured number.
By their numbers in this assay, from the lowest: compound 2; then compound 3; then compound 1.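

Exchanging the chloro of the 4-chlorophenyl group for fluoro gives a 2.1-fold higher number from compound 2 to compound 3 (0.32 log units; beyond the scatter) in this assay, a modest step but one beyond the scatter. This position therefore responds to the choice of halogen, yet the fluoro compound 3 keeps a low number of 11 nM. No available evidence bears on the reason for this step. On these data alone, whether a methoxy group, a nitrile or a trifluoromethyl group at this place would give a lower or a higher number remains open, as does the effect of plain hydrogen there.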